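Ethyl versus isopropyl ester on the methylated core

This account rests on a few compounds, and the source may have more. Where it says the series, first, only, none or still open, it means among the compounds named here.

Compound 1 `CCOC(=O)C1=C(CC)NC(=O)NC1c1ccco1` gives 715 nM in an assay on HEK293 cells for displacement of a labelled ligand from adenosine receptor A2b (Homo sapiens), with a stated time of 30 min; a lower number here means a stronger inhibitor, a higher number a weaker inhibitor. Compound 2 `CCCC1=C(C(=O)OCC)C(c2ccco2)NC(=O)N1` gives 256 nM in this assay. The change between them is methyl in place of hydrogen on a saturated chain carbon, two bonds along the chain from a double-bonded ring carbon, and it produced a 2.8-fold lower number from compound 1 to compound 2 (0.45 log units; beyond the scatter). Compound 3 `CCOC(=O)C1=C(C)N(C)C(=O)NC1c1ccco1` gives 6540 nM in this assay, the highest of the three numbers; compound 1 lies nearest to it and compound 2 furthest. Compound 3 and compound 1 hold the same atoms joined differently; the difference between the two cores is not broken down here.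

Compound 4 `CC1=C(C(=O)OC(C)C)C(c2ccco2)NC(=O)N1C` is not yet measured in this assay. It differs from compound 3 by methyl in place of hydrogen on a saturated chain carbon bound to an oxygen next to a carbonyl group and a saturated chain carbon. Going by the values given here, this is the same kind of change as the one from compound 1 to compound 2, a methyl in place of a hydrogen, but not the same: there the place was on a saturated chain carbon, two bonds along the chain from a double-bonded ring carbon, whereas here it is on a saturated chain carbon bound to an oxygen next to a carbonyl group and a saturated chain carbon. Among the compounds with values here, the measured step from compound 1 to compound 2 stands as the only guide, and its place is different, so the step expected from compound 3 to compound 4 is put smaller, at a 1.5-fold lower number from compound 3 to compound 4 (0.16 log units; within the scatter), resting on a 2.8-fold lower number from compound 1 to compound 2 (0.45 log units; beyond the scatter) alone. Compound 4 is accordingly estimated at 4500 nM in this assay, with a range from 1500 nM to 13000 nM.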

Compound 4, inhibition constant: 1150 nM
Compound 4: middle estimate off by 3.9-fold (0.59 log units), on the high side; the measured number lies below the stated range.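

Going from ethoxycarbonyl to isopropoxycarbonyl on the core of compound 3 gives, in this assay, a 5.7-fold lower number from compound 3 to compound 4 (0.75 log units; beyond the scatter). Set beside the earlier methyl step on the core of compound 1, this step runs the same way, and the two cannot be told apart in size: the same change on two cores in this assay, a 2.8-fold lower number (0.45 log units; beyond the scatter) from compound 1 to compound 2 and a 5.7-fold lower number (0.75 log units; beyond the scatter) from compound 3 to compound 4, 2.0-fold (0.31 log units) apart, within the scatter of two such steps

So within these two pairs, a methyl in place of a hydrogen lowers the number on both cores, but each core supplies only one pair and the methyl sits in a different place in each, so this does not show that a change at one place carries over to the other core, nor that the size of the step would hold there.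

The compounds shown leave open how the isopropoxycarbonyl group would behave on the core of compound 1, and whether the propyl chain of compound 2 would give a comparable step on the core of compound 3. They also leave open what follows at the ester from a longer chain such as butyl, a branched group such as tert-butyl, or a replacement of the ester by a carboxylic acid or an amide.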